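Pentyl for methoxy on the aryl ring of compound 1

The source may hold more compounds than are shown below. What is called first, only, known or untested is meant among the compounds shown, and "the series" means these compounds.

Measured compounds:
- compound 1, `COc1ccc(N2C(=O)NC3(CSC4=C3C(=O)c3ncccc3C4=O)C2=O)cc1`: 50 nM
- compound 2, `O=C1NNC(=O)C2(CSC3=C2C(=O)c2ncccc2C3=O)N1`: 1250 nM
- compound 3, `O=C1NN(c2ccc([N+](=O)[O-])cc2)C(=O)C2(CSC3=C2C(=O)c2ncccc2C3=O)N1`: 550 nM

All three share one core and were read in a functional assay on MCF7 cells (Homo sapiens) for antiproliferative activity, read by MTT assay, with a stated time of 96 h; on this read-out higher numbers stand for weaker inhibition and lower numbers for stronger inhibition. Compound 1 gives the lowest number of the three: compound 3 sits well above it, and compound 2 further still, both gaps beyond the scatter. For the measured compounds named here, the one single-point step within the measured set, a 2.3-fold lower number from compound 2 to compound 3 (0.36 log units; beyond the scatter), concerns a 4-nitrophenyl entering on a ring nitrogen and says nothing about substituents on an aryl ring already present.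

Compound 4, `CCCCCc1ccc(N2C(=O)NC3(CSC4=C3C(=O)c3ncccc3C4=O)C2=O)cc1`, differs from compound 1 by pentyl in place of methoxy on an aromatic carbon. Going by the values given here, no measured pair alters the group on that aromatic carbon, so there is no direct precedent for the size of this step. What the data show is that the aryl-bearing compounds 1 and 3 give the lower numbers, and compound 4 keeps the aryl ring in place. The change is therefore expected to leave compound 4 near compound 1, with a small drift toward a higher number taken as the more likely direction; the estimated step is a 1.6-fold higher number from compound 1 to compound 4 (0.20 log units; within the scatter).

Compound 4 is estimated at 80 nM, within 25 nM to 260 nM.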

Compound 4, half-maximal inhibitory concentration: 250 nM
Compound 4: the middle estimate sits 3.1-fold (0.49 log units) below what was measured, and the stated range covers the measured number.
By their numbers in this assay, from the lowest: compound 1; then compound 4; then compound 3; then compound 2.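

In this assay, for the compounds shown here, the group on this aromatic carbon, para to a large group, clearly bears on the read-out: pentyl in place of methoxy gives a 5.0-fold higher number from compound 1 to compound 4 (0.70 log units; beyond the scatter) and so provides the first measured step at this position. Keeping the aryl ring is therefore not enough to hold the number of compound 1, and of the two groups compared here, methoxy goes with the lower number. The change swaps a group with one hydrogen-bond acceptor for a pentyl chain with none and also raises the heavy-atom count, and no supporting measurement explains the step or separates these two differences.

As far as these compounds go, it remains open whether the higher number follows chain length or the absence of the oxygen, which an ethyl group, a longer alkoxy chain such as pentyloxy, or a hydroxyl at the same place could help to separate. Also open, from the compounds shown here alone, is how an amine or a carboxylic acid at this position would read, and whether any group there can go below the number of compound 1.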